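Longer amino chain on the methoxy member of the series

The source may hold more compounds than are shown below. What is called first, only, known or untested is meant among the compounds shown, and "the series" means these compounds.

compound 1 `CN(C)CCCNc1nc(-c2ccc(F)cc2)nc2ccccc12`: 63000 nM
compound 2 `CN(C)CCCNc1nc(-c2ccccc2)nc2ccccc12`: > 100000 nM (a limit of the assay)
compound 3 `COc1ccc(-c2nc(NCCN(C)C)c3ccccc3n2)cc1`: 57000 nM

In a toxicity assay on cells (Macrophage, Homo sapiens) for inhibition, read by MTT assay (a lower number here means a stronger inhibitor, a higher number a weaker inhibitor), compound 3 (57000 nM) and compound 1 (63000 nM) lie within the scatter of each other. Compound 2 reports only a limit.

Compound 4 `COc1ccc(-c2nc(NCCCN(C)C)c3ccccc3n2)cc1` differs from compound 3 in one place (dimethylamino)methyl in place of dimethylamino on a saturated chain carbon, two bonds along the chain from a nitrogen on an aromatic ring with (dimethylamino)methyl in place of dimethylamino on a saturated chain carbon, two bonds along the chain from a nitrogen on an aromatic ring. Cut one bond further out, this reads (2-(dimethylamino)ethyl)amino to (3-(dimethylamino)propyl)amino.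

Going by the values given here, no measured step changes this chain. Among the compounds with values here, the only measured step is an at least 1.5-fold higher number from compound 1 to compound 2 (0.20 log units; that floor lies within the scatter) with hydrogen in place of fluoro on an aromatic carbon, so it bears on the question only indirectly. Compound 1 (63000 nM) carries the (3-(dimethylamino)propyl)amino group and still gives a number within the scatter of compound 3, so no shift beyond the scatter is expected. Compound 2 carries the same group and goes against this reading. The series already touches the limit of > 100000 nM in this assay, at which 1 of the 3 values shown sits, and compound 4 may also return only a limit.

The expected change is a 1.1-fold higher number from compound 3 to compound 4 (0.02 log units; within the scatter) and no larger shift is anticipated. Compound 4 is estimated at 60000 nM with an expected range from 30000 nM to 100000 nM in this assay.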

Compound 4, half-maximal inhibitory concentration: 67500 nM
For compound 4 the middle estimate is 1.1-fold (0.05 log units) below the measured one; the range from low to high includes it.
By their numbers in this assay, from the lowest: compounds 3, 1 and 4 (each within the scatter of the next). At a limit, above all of these: compound 2.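

In this assay, going by these compounds alone, the chain change from (2-(dimethylamino)ethyl)amino to (3-(dimethylamino)propyl)amino gives a 1.2-fold higher number from compound 3 to compound 4 (0.07 log units; within the scatter), the first direct reading at this saturated chain carbon, and on the methoxy member the two chain lengths cannot be told apart. With the 3-(dimethylamino)propyl chain held constant, methoxy and fluoro on the aromatic carbon also cannot be told apart, as the step shows a 1.1-fold higher number from compound 1 to compound 4 (0.03 log units; within the scatter). The change from hydrogen to methoxy gives an at least 1.4-fold lower number from compound 2 to compound 4 (0.17 log units; that floor lies within the scatter), and this is only a floor set by a limit of the assay, not a measured gap: the limit of > 100000 nM in this assay, at which 1 of the 4 values shown sits.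

The compounds shown leave open whether a longer 4-(dimethylamino)butyl chain, or a morpholine or a primary amine in place of the dimethylamino end, would move the number in this assay beyond the scatter. Also open, on these data alone, is whether the same chain change stays within the scatter on the fluoro and hydrogen members, as only the methoxy pair gives a direct reading of it.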